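This account rests on a few compounds, and the source may have more. Where it says the series, first, only, none or still open, it means among the compounds named here.

Measured in a physicochemical assay for solubility, read by turbidimetry, measured as kinetic solubility, at pH 7.4; a lower number here means a less soluble compound, a higher number a more soluble compound:
- Compound 1 `COc1ccc(F)cc1N1C(=O)CSC1c1cccc(C(=O)NCCCCc2ccccc2)c1`: 10000 nM
- Compound 2 `O=C(NCCCCc1ccccc1)c1cccc(C2SCC(=O)N2c2ccccn2)c1`: 20000 nM
- Compound 3 `O=C(NCCCCc1ccccc1)c1cccc(C2SCC(=O)N2c2ccccc2F)c1`: 10000 nM

Compound 3 gives 10000 nM, level with compound 1 at the digits shown, and all three numbers lie within the usual scatter of one another.

Compound 4 `O=C(NCCCCc1ccccc1)c1cccc(C2SCC(=O)N2c2ccc(C3CC3)cc2)c1` differs from compound 3 in a single group, on an amide-type nitrogen in a ring: 4-cyclopropylphenyl in place of 2-fluorophenyl on an amide-type nitrogen in a ring.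

The measured steps that bear on this change were all made at that same place. They are no change at the digits printed from compound 1 to compound 3 (within the scatter), a 2.0-fold lower number from compound 2 to compound 3 (0.30 log units; within the scatter) and a 2.0-fold higher number from compound 1 to compound 2 (0.30 log units; within the scatter). Each stays within the scatter, so swapping groups here has not yet moved this assay measurably. None of these compounds carries a cyclopropyl group, however, which makes them only a loose guide.

No step beyond the scatter is therefore expected, and the estimated step is a 1.3-fold lower number from compound 3 to compound 4 (0.10 log units; within the scatter). For compound 4 the estimated value is 8000 nM, with an expected range of 3000 nM to 20000 nM.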

Compound 4, solubility: 2000 nM
Beside the measured number, compound 4's estimate is 4.0-fold (0.60 log units) above it; measured number below the stated range.
By their numbers in this assay, from the lowest: compound 4; then compounds 1, 3 and 2 (each within the scatter of the next).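

In this assay this place on the amide-type nitrogen in a ring turns out to be able to shift the number, a shift the first three compounds never showed: there is a 5.0-fold lower number from compound 3 to compound 4 (0.70 log units; beyond the scatter) and also a 5.0-fold lower number from compound 1 to compound 4 (0.70 log units; beyond the scatter) and a 10-fold lower number from compound 2 to compound 4 (1.00 log units; beyond the scatter) and all three steps lie beyond the scatter. So the earlier swaps, which included 2-fluorophenyl, pyridin-2-yl and 5-fluoro-2-methoxyphenyl, did not mark this place as insensitive to every group, and 4-cyclopropylphenyl, with 9 heavy atoms that are all carbon, behaves differently from them. No measurement here explains why this change lowers the number. For the compounds shown here, with only one compound carrying a cyclopropyl group, it remains open whether that small ring itself accounts for the step. Also open, on these data alone, is how a phenyl bearing an amine or a carboxylic acid in its place would read.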